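From 3-fluorophenyl to oxan-4-yl: an expected potency shift

The source may report more compounds than this note shows. Statements on the series, on what has been measured and on what is new or still open speak of the compounds shown alone.

Measured in a functional assay on COR-L23 cells (Homo sapiens) for antiproliferative activity, read by CellTiter-Glo, with a stated time of 72 h; on this read-out lower numbers stand for stronger inhibition and higher numbers for weaker inhibition:
- Compound 1 `O=C(Nc1ccc(CN2Cc3ccccc3C2=O)cc1)N1CCC(c2cccnc2)C1`: > 2500 nM; > 2500 nM (2 entries), a limit of the assay and not a number
- Compound 2 `C[C@H](NC(=O)c1cccc(F)c1)c1ccc(NC(=O)N2CC(c3cccnc3)C2)cc1`: 10 nM

Within the data shown here, compound 2, at 10 nM, carries the only actual number in this assay. Compound 3 `C[C@H](NC(=O)C1CCOCC1)c1ccc(NC(=O)N2CC(c3cccnc3)C2)cc1` has not yet been measured. It carries oxan-4-yl in place of 3-fluorophenyl on a carbonyl carbon. Among the measured compounds shown here, no measured pair shows a change of this kind, so the size of the step rests on judgement alone. A moderate weakening, meaning a higher number, is expected in this assay. The expected step is a 3.0-fold higher number from compound 2 to compound 3 (0.48 log units; beyond the scatter). For compound 3 the estimated value is 30 nM, with an expected range of 6 nM to 150 nM.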

Compound 3, half-maximal inhibitory concentration: 58 nM
For compound 3 the middle estimate is 1.9-fold (0.29 log units) below the measured one, within the range that was stated.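

In this assay, among these compounds, replacing the aromatic 3-fluorophenyl on this carbonyl carbon with the non-aromatic oxan-4-yl gives a 5.8-fold higher number from compound 2 to compound 3 (0.76 log units; beyond the scatter), the only measured step at this position. Potency falls but is not lost: compound 3 still reaches 58 nM, so an aromatic ring is not required here. Nothing measured here explains the size of this step.

The compounds shown leave open whether the step follows the loss of the aromatic ring or the arrival of the ring oxygen; a cyclohexyl group on the same carbonyl carbon would help separate the two.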